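This account rests on a few compounds, and the source may have more. Where it says the series, first, only, none or still open, it means among the compounds named here.

In a functional assay on K562 cells (Homo sapiens) for inhibition, read by luminescence and CellTiter-Glo, with a stated time of 72 h (a higher number here means a weaker inhibitor of growth, a lower number a stronger inhibitor of growth), compound 1 (`CN1CCN(Cc2ccc(NC(=O)Nc3ccc(Oc4ccc5ncncc5c4)cc3)cc2C(F)(F)F)CC1`) gives 2.3 nM. Compound 2 (`CC(C)(C)c1cc(NC(=O)Nc2ccc(Oc3ccc4ncncc4c3)cc2)n(-c2ccc3ncccc3c2)n1`), which is built differently over part of its structure, gives 4 nM. These two numbers lie within the scatter of each other, so the data do not separate the two compounds.

Compound 3 (`CN1CCN(Cc2ccc(NC(=O)Nc3ccc(Oc4ccc5ncccc5c4)cc3)cc2C(F)(F)F)CC1`) has not yet been measured. It keeps all of compound 1 except one group, with quinolin-6-yl in place of quinazolin-6-yl on an oxygen on an aromatic ring. Among the measured compounds shown here, no two measured compounds differ in just one place, so nothing here shows directly how much this kind of change matters, and any forecast is a cautious judgement. With a single group altered and the rest of the molecule unchanged, only a small shift seems likely, perhaps towards a slightly weaker inhibitor. The estimated step of a 2.0-fold higher number from compound 1 to compound 3 (0.29 log units; within the scatter) is expected to be small and not to stand clear of the scatter. For compound 3 the expected value is 4.5 nM, with an estimated range from 1.5 nM to 15 nM.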

Compound 3, concentration for 50% growth inhibition: 6.9 nM
Compound 3: middle estimate off by 1.5-fold (0.19 log units), on the low side; low and high end bracket the measured number.
By their numbers in this assay, from the lowest: compounds 1, 2 and 3 (each within the scatter of the next, the first and the last beyond it).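

In this assay, among the compounds shown here, quinolin-6-yl in place of quinazolin-6-yl on an oxygen on an aromatic ring gives a 3.0-fold higher number from compound 1 to compound 3 (0.48 log units; beyond the scatter), the first step here that isolates a single change, and it shows that this position is not indifferent to such a swap. The change is small on paper: both groups have 10 heavy atoms and two fused six-membered aromatic rings, and the count goes only from 2 hydrogen-bond acceptors to 1 hydrogen-bond acceptor, with one ring nitrogen replaced by carbon. The step is modest, however, and compound 3 still gives 6.9 nM, so the second ring nitrogen of quinazolin-6-yl helps in this series but is not essential, though nothing available here explains the difference.

On these data alone, it remains open whether the same swap would produce a step of similar size in the different structure of compound 2, which also carries the quinazolin-6-yl group on its oxygen. As far as these compounds go, it is also open how far this position tolerates larger changes, such as a single phenyl ring or a quinolin-6-yl group bearing an added amine.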